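Formyl in place of bromo on the core of compound 2

The compounds below may be only part of what the source reports. "The series", "measured", "known", "first", "only" and "open" are said of these compounds alone.

Compound 2 `Clc1ccc(Cc2nn3c(Br)c(-c4ccc(Cl)cc4Cl)nc3s2)cc1` gives 106000 nM in an ADME assay on CCRF-CEM cells (Homo sapiens) for cytotoxicity, with a stated time of 72 h (a lower number here means a stronger inhibitor, a higher number a weaker inhibitor), the lowest of the two numbers seen so far. Compound 1 `Clc1ccc(Cc2nn3c(Br)c(-c4ccc(Br)cc4)nc3s2)cc1` gives 238000 nM in this assay, and the step is a 2.2-fold lower number from compound 1 to compound 2 (0.35 log units; beyond the scatter). Compound 3 `Clc1ccc(Cc2nn3c(Br)c(-c4ccccc4)nc3s2)cc1` reaches only the limit > 250000 nM in this assay. the limit of > 250000 nM in this assay, at which 1 of the 3 values shown sits, is the single limit in the set. Compound 4 `O=Cc1c(-c2ccc(Cl)cc2Cl)nc2sc(Cc3ccc(Cl)cc3)nn12` carries formyl in place of bromo on an aromatic carbon. For the measured compounds named here, the only measured step at that same position is an at least 1.0-fold higher number from compound 1 to compound 3 (0.02 log units; that floor lies within the scatter), which stays inside the scatter, while an at least 2.3-fold higher number from compound 2 to compound 3 (0.37 log units; beyond the scatter) concerns the other aryl group. Going by the values given here, no measured step exchanges bromo for formyl, so the expected step is a 1.0-fold higher number from compound 2 to compound 4 (0.02 log units; within the scatter), no larger than the scatter. Compound 4 is therefore estimated at 110000 nM, between 45000 nM and 250000 nM.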

Compound 4, half-maximal inhibitory concentration: 79000 nM
Compound 4: the middle estimate sits 1.4-fold (0.14 log units) above what was measured; the measured number falls inside the stated range.
By their numbers in this assay, from the lowest: compounds 4 and 2 (each within the scatter of the next); then compound 1. At a limit, above all of these: compound 3.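

In this assay, the carbon of the core that bears bromo in compound 2 also accepts formyl: a 1.3-fold lower number from compound 2 to compound 4 (0.13 log units; within the scatter). On this 2,4-dichlorophenyl background, bromo is therefore not needed to keep the number, and the two compounds cannot be told apart despite the added hydrogen-bond acceptor. Nothing in the data shown bears on a cause for this step. Still open, as far as these compounds go, is whether an amine, a carboxylic acid or a longer chain at this carbon would give a similar number. Also open, from the compounds shown here alone, is whether formyl would give the same result alongside 4-bromophenyl or phenyl.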